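The compounds below may be only part of what the source reports. "The series", "measured", "known", "first", "only" and "open" are said of these compounds alone.

Compound 1 `Clc1cccc(C2CC(c3ccc4c(c3)OCCO4)=NN2c2ccccc2)c1`: 1750 nM
Compound 2 `c1ccc(N2N=C(c3ccc4c(c3)OCCO4)CC2c2ccco2)cc1`: > 100000 nM

Both were tested in a functional assay on WM 266-4 cells (Homo sapiens) for antiproliferative activity, read by MTT assay, with a stated time of 24 h; on this read-out higher numbers stand for weaker inhibition of growth and lower numbers for stronger inhibition of growth. Compound 1 gives 1750 nM. For compound 2 the reported figure > 100000 nM is a limit of the assay rather than a number (the limit of > 100000 nM in this assay, at which 1 of the 2 values shown sits). Compound 3 `Fc1ccc(C2CC(c3ccc4c(c3)OCCO4)=NN2c2ccccc2)cc1` differs from compound 2 by 4-fluorophenyl in place of furan-2-yl on a saturated ring carbon. Among the measured compounds shown here, the only measured step that bears on this change is an at least 57-fold higher number from compound 1 to compound 2 (1.75 log units; beyond the scatter), which runs in the opposite direction; compound 3 undoes that kind of swap, so a large fall in the number is expected. Compound 3 is expected to give 2500 nM (range 700 nM to 10000 nM), an expected step of an at least 40-fold lower number from compound 2 to compound 3 (1.60 log units; beyond the scatter).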

Compound 3, concentration for 50% growth inhibition: 6050 nM
For compound 3 the middle estimate is 2.4-fold (0.38 log units) below the measured one; the measured number falls inside the stated range.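

In this assay, the loss seen with furan-2-yl on this saturated ring carbon is not a loss of every replacement for 3-chlorophenyl, since 4-fluorophenyl gives an at least 16-fold lower number from compound 2 to compound 3 (1.21 log units; beyond the scatter). The two halogen-bearing phenyl groups still differ, with a 3.5-fold higher number from compound 1 to compound 3 (0.54 log units; beyond the scatter). The figure for compound 2 is a limit of the assay and not a number: the limit of > 100000 nM in this assay, at which 1 of the 3 values shown sits.

Compounds 1 and 3 differ in both the halogen and where it sits, so those two effects cannot be separated. Also open, as far as these compounds go, is how an unsubstituted phenyl or a cyclohexyl group would behave on this carbon.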